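Methoxy on the benzyl ring: a second position tested

This account rests on a few compounds, and the source may have more. Where it says the series, first, only, none or still open, it means among the compounds named here.

Compounds measured so far:
compound 1 `Clc1cccc(-n2ncnc2Nc2ccccc2)c1Cl` — 363 nM
compound 2 `Clc1cccc(-n2ncnc2NCc2ccccc2)c1Cl` — 47.9 nM
compound 3 `COc1ccccc1CNc1ncnn1-c1cccc(Cl)c1Cl` — 57.5 nM

In a functional assay for antagonist activity at P2X purinoceptor 7 (Homo sapiens), read by FLIPR and calcium flux (on this read-out higher numbers stand for weaker inhibition and lower numbers for stronger inhibition), compound 2 has the lowest number of the three, but its gap to compound 3 is within the scatter. The step from compound 1 to compound 2, a 7.6-fold lower number from compound 1 to compound 2 (0.88 log units; beyond the scatter), was beyond the scatter; the step from compound 2 to compound 3, a 1.2-fold higher number from compound 2 to compound 3 (0.08 log units; within the scatter), was not.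

Compound 4 `COc1ccc(CNc2ncnn2-c2cccc(Cl)c2Cl)cc1` differs from compound 2 by methoxy in place of hydrogen on an aromatic carbon. Among the measured compounds shown here, only the step to compound 3 bears on it, and that step stayed within the scatter, so no shift beyond the scatter is expected in this assay, with a step estimated as a 1.3-fold higher number from compound 2 to compound 4 (0.10 log units; within the scatter). Compound 4 is thus expected to give 60 nM, within 25 nM to 150 nM.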

Compound 4, half-maximal inhibitory concentration: 1620 nM
For compound 4 the middle estimate is 27-fold (1.43 log units) below the measured one; measured number above the stated range.
By their numbers in this assay, from the lowest: compounds 2 and 3 (each within the scatter of the next); then compound 1; then compound 4.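

In this assay, the same swap of hydrogen for methoxy gives a 34-fold higher number from compound 2 to compound 4 (1.53 log units; beyond the scatter), so this change does not act alike everywhere on the benzyl ring. Para to a large group, methoxy costs much inhibition, while compound 3, with its methoxy placed elsewhere, gives 57.5 nM. Nothing measured here explains this loss.

As far as these compounds go, it remains open whether the loss belongs to methoxy itself or to any group at this place. A fluorine, a methyl or an amine there would tell these two readings apart.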